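From 2-Methoxyphenyl to 2,6-Difluorophenyl on a Carbonyl Carbon

A few compounds are considered here, and "the series" means these few. Any claim that something is new, unique, unknown or untested is made for them only; others in the source may bear on it.

Compound 1 `Nc1ccccc1NC(=O)c1ccc(CNC(=O)c2n[nH]cc2NC(=O)c2ccccc2Cl)cc1` and compound 2 `COc1ccccc1C(=O)Nc1c[nH]nc1C(=O)NCc1ccc(C(=O)Nc2ccccc2N)cc1` share the same core and differ in one place. In a functional assay on NCI-H460 cells (Homo sapiens) for inhibition, read by CCK-8 assay, with a stated time of 72 h (on this read-out lower numbers stand for stronger inhibition and higher numbers for weaker inhibition), compound 1 gives 6360 nM and compound 2 gives 7350 nM. For the measured compounds named here, these are the only two measurements so far, and they lie within the usual scatter of each other, so compound 2 has no clear rank.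

The next compound, compound 3 `Nc1ccccc1NC(=O)c1ccc(CNC(=O)c2n[nH]cc2NC(=O)c2c(F)cccc2F)cc1`, has not yet been measured. Its difference from compound 2 is a single swap (2,6-difluorophenyl in place of 2-methoxyphenyl on a carbonyl carbon), with 2,6-difluorophenyl in place of 2-methoxyphenyl on a carbonyl carbon.

Going by the values given here, the one measured step that bears on this swap is a 1.2-fold higher number from compound 1 to compound 2 (0.06 log units; within the scatter), which put methoxy in place of chloro on an aromatic carbon. That small step gives no reason to expect a shift beyond the scatter in this assay, although it is thin evidence, and no compound carrying fluorine has been measured. The estimated step is a 1.2-fold lower number from compound 2 to compound 3 (0.09 log units; within the scatter), which would lie within the scatter. For compound 3 the expected value is 6000 nM, with an estimated range of 2200 nM to 14000 nM.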

Compound 3, half-maximal inhibitory concentration: 7790 nM
Beside the measured number, compound 3's estimate is 1.3-fold (0.11 log units) below it; the range from low to high includes it.
By their numbers in this assay, from the lowest: compounds 1, 2 and 3 (each within the scatter of the next).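

In this assay this position, the aromatic group on the carbonyl carbon, has now carried three different groups, and 2,6-difluorophenyl in place of 2-methoxyphenyl gives a 1.1-fold higher number from compound 2 to compound 3 (0.03 log units; within the scatter) while 2,6-difluorophenyl in place of 2-chlorophenyl gives a 1.2-fold higher number from compound 1 to compound 3 (0.09 log units; within the scatter) on the same read-out. For the compounds shown here, this is the first sight of fluorine at this position, and the change also removes the hydrogen-bond acceptor counted on 2-methoxyphenyl, yet compounds 1, 2 and 3 all stay within the scatter of one another, so this read-out does not separate these three groups. No measured evidence is available to explain why these groups read alike.

As far as these compounds go, all three groups are substituted phenyl rings, so it remains open whether this position would respond to a different kind of group, such as an amine, a carboxylic acid or a cyclohexyl ring in place of the phenyl ring. From the compounds shown here alone, it also remains open whether a change at another place on the shared core would move the number beyond the scatter.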